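Cyclohexyl for 2-fluorophenyl: expected toxicity of compound 4

The source may hold more compounds than are shown below. What is called first, only, known or untested is meant among the compounds shown, and "the series" means these compounds.

Three members of this series have been measured. Compound 1 `COc1ccccc1-c1cnc(NC(=O)c2ccc(F)cc2)n1C` reaches only a limit in a toxicity assay on THP-1 cells (Homo sapiens) for inhibition (on this read-out lower numbers stand for higher toxicity in this test and higher numbers for lower toxicity in this test), reported as > 100000 nM. Compound 2 `CCCCn1c(-c2ccc(OC)cc2)cnc1NC(=O)c1ccc(F)cc1` likewise reaches only a limit in this assay, > 100000 nM. Compound 3 `COc1ccc(-c2cnc(NC(=O)c3ccccc3F)n2C)cc1` also gives only a limit in this assay, > 100000 nM. Among the measured compounds shown here, compound 3 therefore stands at the top of the measured range together with the other two, as the limit of > 100000 nM in this assay, at which 3 of the 3 values shown sit, records; no value in the set is a number, so no step between measured compounds can be drawn, and nothing separates compound 3 from compound 1 or compound 2.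

Compound 4 `COc1ccc(-c2cnc(NC(=O)C3CCCCC3)n2C)cc1` has not been measured. It differs from compound 3 in one place: cyclohexyl in place of 2-fluorophenyl on a carbonyl carbon. The change is cyclohexyl in place of 2-fluorophenyl on a carbonyl carbon. With every measured compound sitting at the limit, there is nothing to project a shift from. The expected step of a number no higher from compound 3 to compound 4 (the limit leaves the size open) is none beyond the scatter. Compound 4 is expected to give 100000 nM in this assay, within 30000 nM to 300000 nM, most probably again reported only as a limit.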

Compound 4, half-maximal cytotoxic concentration: > 100000 nM
Compound 4 ended at the assay's limit; the forecaster's own chance of this, stated with the estimate: 80%; the middle value lies on the limit itself.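

Among the compounds shown here, compound 3 and compound 4 both stand at the limit of the assay rather than at a number, so no step between them can be read. The compounds shown leave open whether cyclohexyl in place of 2-fluorophenyl on a carbonyl carbon changes anything in this assay; none of them carries a numerical value.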